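A Chloro Step from Compound 2

A few compounds are considered here, and "the series" means these few. Any claim that something is new, unique, unknown or untested is made for them only; others in the source may bear on it.

Measured in a functional assay on KB 3-1 cells (Homo sapiens) for cytotoxicity, read by MTT assay, with a stated time of 68 h; on this read-out lower numbers stand for stronger inhibition and higher numbers for weaker inhibition:
- compound 1 `Cc1ccc(-c2cccc(NC(=O)C(Cl)Cl)c2)cc1`: > 50000 nM (a limit)
- compound 2 `O=C(Nc1cccc(-c2ccccc2)c1)C(Cl)Cl`: 46800 nM

Compound 1 gives only a limit, > 50000 nM. Within the data shown here, compound 2, at 46800 nM, holds the only exact number so far. Compound 3 `O=C(Nc1cccc(-c2ccc(Cl)cc2)c1)C(Cl)Cl` departs from compound 2 by one change: chloro in place of hydrogen on an aromatic carbon. Among the measured compounds shown here, the only measured step, hydrogen in place of methyl on an aromatic carbon, is an at least 1.0-fold lower number from compound 1 to compound 2 (0.02 log units; that floor lies within the scatter). That step offers no firm guide, so little movement is expected in this assay, with a slight lean toward lower numbers. The expected change is a 1.6-fold lower number from compound 2 to compound 3 (0.19 log units; within the scatter). Compound 3 is estimated at 30000 nM, within an expected range of 12000 nM to 50000 nM.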

Compound 3, half-maximal inhibitory concentration: 38200 nM
Compound 3: the middle estimate sits 1.3-fold (0.10 log units) below what was measured; the range from low to high includes it.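

In this assay, chloro in place of hydrogen on the aromatic carbon para to a large group gives a 1.2-fold lower number from compound 2 to compound 3 (0.09 log units; within the scatter), so a real heavy atom at this position leaves the number indistinguishable from that of the unsubstituted compound. Chloro in place of methyl gives an at least 1.3-fold lower number from compound 1 to compound 3 (0.11 log units; that floor lies within the scatter), a floor set by a limit: the limit of > 50000 nM in this assay, at which 1 of the 3 values shown sits.

Neither step therefore shows a change at this position beyond the scatter. On these data alone, whether an amine or a carboxylic acid on this carbon would move the number beyond the scatter remains open.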